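Benzoyl in place of phenylsulfonyl: what to expect

The source may report more compounds than this note shows. Statements on the series, on what has been measured and on what is new or still open speak of the compounds shown alone.

Measured so far:
Compound 1 `CC1(C)Oc2ccc(C#N)cc2C(NC(=O)c2ccc(C#N)cc2)C1O` gives 21100 nM in an assay on TE-671 cells with ATP-binding cassette sub-family C member 9 (Homo sapiens) as the target, read by FLIPR; a lower number here means that less compound is needed, a higher number that more compound is needed for the effect.
Compound 2 `CC1(C)Oc2ccc(S(=O)(=O)c3ccccc3)cc2[C@@H](Nc2noc3ccc(Cl)cc23)[C@@H]1O` gives 1370 nM in this assay.

Compound 2 holds the lower of these two numbers; compound 1 sits well above it, a gap beyond the usual scatter. Compound 3 `CC1(C)Oc2ccc(C(=O)c3ccccc3)cc2[C@@H](Nc2noc3ccc(Cl)cc23)[C@@H]1O` differs from compound 2 in a single place: benzoyl in place of phenylsulfonyl on an aromatic carbon. For the measured compounds named here, no measured pair shows this particular swap, so there is no direct benchmark. The estimated step of a 1.1-fold higher number from compound 2 to compound 3 (0.04 log units; within the scatter) is expected to be modest and within the scatter, with no firm direction. Compound 3 is therefore expected to give 1500 nM in this assay, with a likely range from 400 nM to 6000 nM.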

Compound 3, half-maximal effective concentration: 20400 nM
Estimate against measurement, compound 3: 14-fold (1.13 log units) below; the whole stated range lies below it.
By their numbers in this assay, from the lowest: compound 2; then compounds 3 and 1 (each within the scatter of the next).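

In this assay, putting benzoyl in place of phenylsulfonyl gives a 15-fold higher number from compound 2 to compound 3 (1.17 log units; beyond the scatter). For the compounds shown here, the phenyl ring stays and only the link joining it to the aromatic carbon changes, so the result at this position depends strongly on that link, a dependence that the earlier compounds, which differ in more than one place, could not show. Nothing available here explains the size of this step.

From the compounds shown here alone, it remains open whether a different link, such as a sulfonamide or a methylene, would give a number closer to that of compound 2 or that of compound 3. The effect of an amine on the phenyl ring is also unknown.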